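A few compounds are considered here, and "the series" means these few. Any claim that something is new, unique, unknown or untested is made for them only; others in the source may bear on it.

Measured so far in a functional assay on CWR22R cells (Homo sapiens) for antiproliferative activity, read by propidium iodide staining, with a stated time of 96 h; a higher number here means a weaker inhibitor, a lower number a stronger inhibitor:
compound 1 `CC(O)(CSc1ccc(S(F)(F)(F)(F)F)cc1)C(=O)Nc1ccc([N+](=O)[O-])c(C(F)(F)F)c1` gives 9200 nM
compound 2 `CC(O)(CSc1cccc(S(F)(F)(F)(F)F)c1)C(=O)Nc1ccc(C#N)cc1C(F)(F)F` gives 21600 nM
compound 3 `CC(O)(CS(=O)(=O)c1ccc(F)cc1)C(=O)Nc1ccc(S(F)(F)(F)(F)F)cc1` gives 20600 nM

Compound 3 stands within the scatter of compound 2, so these two cannot be told apart on the present numbers. Compound 1 gives a lower number than compound 3, and that gap lies beyond the scatter.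

Compound 4 `CC(O)(CS(=O)(=O)c1ccc(OC(F)(F)F)cc1)C(=O)Nc1ccc(S(F)(F)(F)(F)F)cc1` is not yet measured. It is compound 3 with trifluoromethoxy in place of fluoro on an aromatic carbon, para to a large group (trifluoromethoxy in place of fluoro on an aromatic carbon). The same difference, cut one bond further out, reads 4-fluorophenyl to 4-(trifluoromethoxy)phenyl.

Going by the values given here, no two measured compounds differ in one place only, so the series offers no measured step to carry over to this change. The expectation therefore rests on compound 3 as the starting point and on how narrowly the three measured values are spread. No step beyond the scatter is expected in this assay, with a slight lean towards a lower number. The estimated change is a 1.4-fold lower number from compound 3 to compound 4 (0.14 log units; within the scatter) and would remain within the scatter. For compound 4 the estimate is 15000 nM, with an expected range from 7000 nM to 32000 nM.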

Compound 4, half-maximal inhibitory concentration: 51900 nM
Compound 4: the middle estimate sits 3.5-fold (0.54 log units) below what was measured; the whole stated range lies below it.
By their numbers in this assay, from the lowest: compound 1; then compounds 3 and 2 (each within the scatter of the next); then compound 4.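

In this assay, the series now has its first measured step that differs in one place only, a 2.5-fold higher number from compound 3 to compound 4 (0.40 log units; beyond the scatter), and it lies beyond the scatter. On this aromatic carbon, para to a large group, the position is therefore not indifferent to what it carries: trifluoromethoxy, with more heavy atoms than fluoro and a hydrogen-bond acceptor, goes with a weaker inhibitor in this pair. No measured property of these compounds bears on the step, which stands as an observation on a single pair.

Going by these compounds, it remains open whether the rise in the number follows the size of the group at this position, and a methoxy group, a chlorine atom or a plain hydrogen there would separate the oxygen link from the fluorinated carbon and from fluoro itself. Going by these compounds alone, it also remains open whether the same change from fluoro to trifluoromethoxy gives a step of similar size on the core of compound 1 or compound 2, where no such pair is available.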